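Chain Length and Amide Cap in Hexokinase-2 Nucleotide Analogues

The source may report more compounds than this note shows. Statements on the series, on what has been measured and on what is new or still open speak of the compounds shown alone.

Measured compounds:
Compound 1, `O=C(CI)NCCCCNc1ncnc2c1ncn2[C@@H]1O[C@H](COP(=O)(O)OP(=O)(O)OP(=O)(O)O)[C@@H](O)[C@H]1O`, gives 0% in an assay on isolated protein for inhibition of hexokinase-2 (Rattus norvegicus), with a stated time of 6 h, tested at 10 mM; on this read-out higher numbers stand for more inhibition at the one concentration tested (going by the name of the read-out) and lower numbers for less inhibition.
Compound 2, `O=C(CI)NCCNc1ncnc2c1ncn2[C@@H]1O[C@H](COP(=O)(O)OP(=O)(O)OP(=O)(O)O)[C@@H](O)[C@H]1O`, gives 0%.

Compound 2 stands level with compound 1 at the digits shown; the two are within the scatter of each other, so the inhibition in this assay reads level for the two. For the measured compounds named here, the one step that joins them, no change at the digits printed from compound 1 to compound 2 (within the scatter), shortened the chain between the amide and the shared core and moved the read-out not at all beyond the scatter.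

Compound 3, `CC(=O)NCCCCCCCCNc1ncnc2c1ncn2[C@@H]1O[C@H](COP(=O)(O)OP(=O)(O)OP(=O)(O)O)[C@@H](O)[C@H]1O`, has not yet been measured in this assay. Its difference from compound 2 is 6-acetamidohexyl in place of ((iodomethyl)carbonyl)amino on a saturated chain carbon, two bonds along the chain from a nitrogen on an aromatic ring. Two things alter at once: the chain grows much longer, and the iodine-bearing cap is exchanged for a plain acetamide. Going by the values given here, only the step from compound 1 to compound 2 bears on this, and it addressed chain length alone, showing no change. Nothing measured addresses the loss of iodine. With both measured compounds at the floor, the expected step is no change at the digits printed from compound 2 to compound 3 (within the scatter), none beyond the scatter. Compound 3 is therefore estimated at 0%, between 0% and 10%.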

Compound 3, a percentage reported as inhibition, at one concentration (the size of the read-out at that concentration, not a potency): -12%
Beside the measured number, compound 3's estimate is 12 percentage points above it; the whole stated range lies above it.
By their numbers in this assay, from the lowest: compound 3; then compounds 1 and 2 (each within the scatter of the next).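

In this assay, for the compounds shown here, the exchange of ((iodomethyl)carbonyl)amino for 6-acetamidohexyl, on a saturated chain carbon two bonds along the chain from a nitrogen on an aromatic ring, gives a number 12 percentage points lower from compound 2 to compound 3 (beyond the scatter) and is the first step at this position to pass the scatter. The exchange of the same group for 4-acetamidobutyl, on a saturated chain carbon four bonds along the chain from a nitrogen on an aromatic ring, gives a number 12 percentage points lower from compound 1 to compound 3 (beyond the scatter) and so points the same way from the other iodine-bearing compound. Both steps run downward, and since lower numbers on this read-out stand for less inhibition, the long acetamide-capped chain of compound 3 brings no gain in inhibition, and nothing measured here accounts for that drop.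

Chain length and cap changed together in these steps, so the compounds shown cannot tell whether the longer chain or the loss of the iodine carries the change. Also open, going by these compounds, is how a free amine or a carboxylic acid at the end of the chain would read in this assay at this position.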